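A few compounds are considered here, and "the series" means these few. Any claim that something is new, unique, unknown or untested is made for them only; others in the source may bear on it.

Measured compounds:
- compound 1, `O=C(CSc1nc(Nc2ccccc2)c2ccccc2n1)Nc1ccc(Cl)cc1Cl`: 12300 nM
- compound 2, `C=CC(=O)Nc1cccc(NC(=O)CSc2nc(Nc3cccc(Br)c3)c3ccccc3n2)c1`: 11900 nM

In a functional assay on MGC-803 cells (Homo sapiens) for inhibition, read by MTT assay, with a stated time of 72 h (on this read-out higher numbers stand for weaker inhibition and lower numbers for stronger inhibition), compound 1 gives 12300 nM and compound 2 gives 11900 nM. Compound 2 has the lower of the two numbers, but the two values lie within the scatter of each other, so nothing separates them. Compound 3, `C=CC(=O)Nc1cccc(NC(=O)CSc2nc(Nc3ccc(Cl)cc3Cl)c3ccccc3n2)c1`, has not been measured. It differs from compound 2 in one place: 2,4-dichlorophenyl in place of 3-bromophenyl on a nitrogen on an aromatic ring The 2,4-dichlorophenyl group that enters is the same group that compound 1 carries on that nitrogen, and compound 1 sits at nearly the same number as compound 2. Within the data shown here, with no measured step to go on, the expectation for compound 3 is a step from compound 2 of no more than the scatter, in either direction. Compound 3 is therefore expected to come out around 11000 nM, within a range of 5000 nM to 25000 nM, which corresponds to an expected step of a 1.1-fold lower number from compound 2 to compound 3 (0.03 log units; within the scatter).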

Compound 3, half-maximal inhibitory concentration: 12100 nM
The estimate for compound 3 lay 1.1-fold (0.04 log units) below the measured number; low and high end bracket the measured number.
By their numbers in this assay, from the lowest: compounds 2, 3 and 1 (each within the scatter of the next).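

In this assay, among these compounds, 2,4-dichlorophenyl in place of 3-bromophenyl on a nitrogen on an aromatic ring gives a 1.0-fold higher number from compound 2 to compound 3 (0.01 log units; within the scatter), the first step that can be read between two compounds differing in one place. This position therefore holds either substituted phenyl group, one carrying a single bromine and the other two chlorines, without the read-out telling them apart. Nothing at hand bears on why these two compounds read alike. On these data alone, it remains open whether a group of another kind on that nitrogen, such as a morpholine, a carboxylic acid or a longer alkyl chain, would move the number beyond the scatter. Nor does any pair shown isolate the acrylamide, which compound 1 lacks.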